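Carbamate to oxadiazolylmethyl swap on the ring amine

The source may hold more compounds than are shown below. What is called first, only, known or untested is meant among the compounds shown, and "the series" means these compounds.

Compound 2 `CC(C)OC(=O)N1CCC(O[C@H]2CC[C@H](Oc3cnc(S(C)(=O)=O)cn3)CC2)CC1` holds the higher of the two numbers in hand in a functional assay on isolated protein for agonist activity at Glucose-dependent insulinotropic receptor (Rattus norvegicus), read by HTRF and cAMP accumulation; on this read-out higher numbers stand for an effect only at larger amounts of compound and lower numbers for an effect already at smaller amounts: compound 2 gives 119 nM, while compound 1 `CC(C)(C)OC(=O)N1CCC(O[C@H]2CC[C@H](Oc3cnc(C#N)cn3)CC2)CC1` gives 28.4 nM, a gap beyond the scatter. Compound 3 `CC(F)Cc1nc(CN2CCC(O[C@H]3CC[C@H](Oc4cnc(S(C)(=O)=O)cn4)CC3)CC2)no1` has not yet been measured. The change from compound 2 to compound 3 is (5-(2-fluoropropyl)-1,2,4-oxadiazol-3-yl)methyl in place of isopropoxycarbonyl on an amine nitrogen in a ring. Among the compounds with values here, no measured pair shows this change, so there is no step to lean on. The expected step is a 2.0-fold lower number from compound 2 to compound 3 (0.30 log units; within the scatter), toward a somewhat lower number, about the size of the scatter. Compound 3 is expected to give 60 nM, within 15 nM to 250 nM.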

Compound 3, half-maximal effective concentration: 267 nM
Beside the measured number, compound 3's estimate is 4.5-fold (0.65 log units) below it; the whole stated range lies below it.
By their numbers in this assay, from the lowest: compound 1; then compound 2; then compound 3.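

In this assay, (5-(2-fluoropropyl)-1,2,4-oxadiazol-3-yl)methyl in place of isopropoxycarbonyl on an amine nitrogen in a ring gives a 2.2-fold higher number from compound 2 to compound 3 (0.35 log units; beyond the scatter). This position therefore accepts a five-membered aromatic ring in place of the carbonyl-bearing group, with a modest change in the read-out. Nothing at hand accounts for the size or direction of this step.

On these data alone, whether the fluorine or the oxadiazole ring drives the step remains open. So does the outcome with a pyrimidine ring or a plain butyl chain on this nitrogen.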